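The source may hold more compounds than are shown below. What is called first, only, known or untested is meant among the compounds shown, and "the series" means these compounds.

Measured compounds:
Compound 1 `O=C(Nc1ccc(F)c(C(F)(F)F)c1)NC1(C(=O)O)CC1` — in an ADME assay on microsomes from liver (Mus musculus) for metabolic stability, using NADPH, with a stated time of 60 min (a lower number here means slower removal, a higher number faster removal of the compound), compound 1 gives < 7 uL/min, which is a limit of the assay and not a number.
Compound 2 `O=C(Nc1ccc(F)c(C(F)(F)F)c1)NC1(C(=O)O)CCC1` — in this assay compound 2 gives < 7 uL/min, again a limit of the assay rather than a number.

Compound 2 thus stands at the floor of what this assay reports, where both shown values sit (the limit of < 7 uL/min in this assay, at which 2 of the 2 values shown sit). For the measured compounds named here, the only measured step, a step that the two limits leave unreadable from compound 1 to compound 2, joins two limits and therefore has no readable size.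

Compound 3 `CC(C)(NC(=O)Nc1ccc(F)c(C(F)(F)F)c1)C(N)=O` differs from compound 2 in one place: 1-carbamoyl-1-methylethyl in place of 1-carboxycyclobutyl on an amide-type nitrogen. No measured step involves this kind of change, so nothing from the shown pair gives its direction or size. What the data do offer is that both compounds 1 and 2 sit at the limit (the limit of < 7 uL/min in this assay, at which 2 of the 2 values shown sit), and compound 3 keeps the shared core of compound 2 unchanged.

The step is expected to be small, a number no lower from compound 2 to compound 3 (the limit leaves the size open). Compound 3 is therefore estimated at 7 uL/min in this assay, within a range from 3 uL/min to 20 uL/min, with a fair chance that only a limit is reported.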

Compound 3, intrinsic clearance in a liver preparation (reported as CLH), per the amount of preparation that the assay uses in the Mus musculus assay: 18 uL/min
Compound 3: middle estimate off by 2.6-fold (0.41 log units), on the low side; low and high end bracket the measured number.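

In the Mus musculus assay, the 1-carbamoyl-1-methylethyl group on the amide-type nitrogen gives the first reading off the floor of the assay, with an at least 2.5-fold higher number from compound 2 to compound 3 (0.41 log units; beyond the scatter) and an at least 2.5-fold higher number from compound 1 to compound 3 (0.41 log units; beyond the scatter), so the read-out at this position can move with the group placed there. Both steps start from a limit and so fix only the smallest size the change can have, while the step between the two carboxy compounds, compound 1 and compound 2, cannot be read: the limit of < 7 uL/min in the Mus musculus assay, at which 2 of the 3 values shown sit. For the compounds shown here, in a physicochemical assay for solubility, read by nephelometry, measured as kinetic solubility, at pH 2, tested at 10 mg/mL (on this read-out lower numbers stand for lower solubility and higher numbers for higher solubility), compound 2 gives 50 ug/mL and compound 3 gives 50 ug/mL, which is no change at the digits printed from compound 2 to compound 3 (within the scatter), so the step seen for clearance has no counterpart on this read-out.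

The change from compound 2 to compound 3 removes the four-membered ring and swaps the carboxy group for a carbamoyl group in one move, so the compounds shown do not tell which of the two carries the step. From the compounds shown here alone, a 1-carboxy-1-methylethyl or a 1-carbamoylcyclobutyl group on the same nitrogen would separate the two, and how far the true step extends beyond its printed minimum also stays open.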